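A few compounds are considered here, and "the series" means these few. Any claim that something is new, unique, unknown or untested is made for them only; others in the source may bear on it.

In an ADME assay on BJ cells (Homo sapiens) for cytotoxicity, read by fluorescence, with a stated time of 24 h (on this read-out higher numbers stand for weaker inhibition and lower numbers for stronger inhibition), compound 1 (`CCOC(=O)c1sc(N/N=C/c2c(-c3ccc([N+](=O)[O-])cc3)[nH]c3ccccc23)nc1C`) gives 50000 nM. Compound 2 (`CC1S/C(=N\N=C\c2c(-c3ccc(Br)cc3)[nH]c3ccccc23)NC1=O`) has no exact number, only a limit of the assay, > 50000 nM. Compound 3 (`CCC1S/C(=N\N=C\c2c(-c3ccc(Br)cc3)[nH]c3ccccc23)NC1=O`) has not yet been measured, and it differs from compound 2 in one place: methyl in place of hydrogen on a saturated chain carbon bound to a saturated ring carbon. This is methyl in place of hydrogen on a saturated chain carbon bound to a saturated ring carbon, so that methyl becomes ethyl. Among the compounds with values here, no step between measured compounds is available to show how much such a change matters in this assay. The expectation is therefore a modest one, with no shift beyond the scatter in either direction. The expected step is a number no higher from compound 2 to compound 3 (the limit leaves the size open). Compound 3 is estimated at 50000 nM, with an expected range of 20000 nM to 70000 nM.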

Compound 3, half-maximal inhibitory concentration: 7450 nM
Compound 3: the middle estimate sits 6.7-fold (0.83 log units) above what was measured; measured number outside the range, below it.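

In this assay, within the data shown here, the earlier compounds gave no step at this place, and the first one now read is not small: methyl in place of hydrogen on a saturated chain carbon bound to a saturated ring carbon, turning methyl into ethyl, gives an at least 6.7-fold lower number from compound 2 to compound 3 (0.82 log units; beyond the scatter). A change of one methyl at this place is therefore enough to bring a measurable cytotoxic effect into this series, where a lower number stands for stronger inhibition. The step is a bound and not a full size, because compound 2 has only a limit of the assay: the limit of > 50000 nM in this assay, at which 1 of the 3 values shown sits.

From the compounds shown here alone, whether a longer chain such as propyl, or an amine or a carboxylic acid, would take the number further down at this place remains open. The trend rests on this single pair, and what in the ethyl group drives the step cannot be told from it.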